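Methyl to hydrogen on an aryl oxygen: toxicity unchanged

A few compounds are considered here, and "the series" means these few. Any claim that something is new, unique, unknown or untested is made for them only; others in the source may bear on it.

Measured compounds:
compound 1, `COc1cc(-c2nn(-c3cccc(NC(=O)Nc4cc(C(F)(F)F)cc(C(F)(F)F)c4)c3)cc2-c2ccncc2)ccc1Cl` — > 50000 nM
compound 2, `O=C(Nc1cccc(-n2cc(-c3ccncc3)c(-c3ccc(Cl)c(O)c3)n2)c1)Nc1cc(C(F)(F)F)cc(C(F)(F)F)c1` — > 50000 nM
compound 3, `COc1cc(-c2nn(-c3cccc(NC(=O)Nc4ccc(Cl)c(C(F)(F)F)c4)c3)cc2-c2ccncc2)ccc1Cl` — > 32500 nM

In a functional assay on SNB-19 cells (Homo sapiens) for inhibition, read by sulforhodamine B assay, with a stated time of 48 h (on this read-out higher numbers stand for lower toxicity in this test and lower numbers for higher toxicity in this test), compound 1 gives > 50000 nM, which is a limit of the assay rather than a number. Compound 2 gives > 50000 nM, again a limit. The change from compound 1 to compound 2 is hydrogen in place of methyl on an oxygen on an aromatic ring, and the step it made is a step that the two limits leave unreadable from compound 1 to compound 2. Compounds 1 and 2 both sit at the limit of > 50000 nM in this assay, at which 2 of the 3 values shown sit.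

Compound 3 carries a different urea end; the difference between its core and that of compound 1 is not broken down here. Compound 3 gives > 32500 nM in this assay, which is a limit and not a number; it sits at the limit of > 32500 nM in this assay, at which 1 of the 3 values shown sits.

Compound 4, `O=C(Nc1cccc(-n2cc(-c3ccncc3)c(-c3ccc(Cl)c(O)c3)n2)c1)Nc1ccc(Cl)c(C(F)(F)F)c1`, is not yet measured. It differs from compound 3 by hydrogen in place of methyl on an oxygen on an aromatic ring, the same change as that from compound 1 to compound 2, since both place lines read alike. Because the earlier pair showed a step that the two limits leave unreadable from compound 1 to compound 2, no readable movement is available to carry over, and all three measured compounds lie at limits of the assay. Compound 4 is therefore expected to give 50000 nM, within 20000 nM to 150000 nM. The step this estimate means is a step that the limit leaves unreadable from compound 3 to compound 4, expected to be essentially flat, and the most likely outcome is that this assay again reports only a limit for compound 4.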

Compound 4, concentration lethal to 50% of the cells: > 32500 nM
Compound 4 gave a limit, no number (the forecaster's own chance of this, stated with the estimate: 85%); the middle value lies beyond the limit too.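

Compound 3 and compound 4 both stand at limits of this assay rather than at numbers, and the step between them, methoxy to hydroxy, cannot be read. None of the four compounds gives a number in this assay, which leaves open whether the change from 4-chloro-3-methoxyphenyl to 4-chloro-3-hydroxyphenyl alters toxicity in either pair.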